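Swapping the Oxadiazole Arm for a Fluorophenyl Thiazole

The compounds below may be only part of what the source reports. "The series", "measured", "known", "first", "only" and "open" are said of these compounds alone.

Measured compounds:
compound 1, `Cc1noc(C)c1-c1ccc2c(c1)C(c1ccccc1)N(Cc1nnc(-c3ccccc3)o1)C(=O)N2C`: 34.7%
compound 2, `Cc1noc(C)c1-c1ccc2c(c1)C(c1ccccc1)N(Cc1nc(-c3ccccc3)cs1)C(=O)N2C`: 44.5%

In a functional assay on HepG2 cells (Homo sapiens) for inhibition, read by MTT assay, with a stated time of 48 h, tested at 2 uM (on this read-out lower numbers stand for less inhibition and higher numbers for more inhibition at the one concentration tested (going by the name of the read-out)), compound 1 gives 34.7% and stands at the lower of the two numbers, although the gap to compound 2 is within the scatter. Compound 2 gives 44.5% in this assay, and the step of a number 9.8 percentage points higher from compound 1 to compound 2 (within the scatter) is the only one measured so far.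

Compound 3 is `Cc1noc(C)c1-c1ccc2c(c1)C(c1ccccc1)N(Cc1nc(-c3ccc(F)cc3)cs1)C(=O)N2C`. It differs from compound 1 by 4-(4-fluorophenyl)-1,3-thiazol-2-yl in place of 5-phenyl-1,3,4-oxadiazol-2-yl on a saturated chain carbon bound to an amide-type nitrogen in a ring. The measured step from compound 1 to compound 2 bears on this change, since it makes the same exchange of the oxadiazole for a phenyl-thiazole without fluorine, and it was within the scatter. Among the measured compounds shown here, no measured compound shows the effect of the fluorine on that phenyl. The expected step is therefore a number 10.3 percentage points higher from compound 1 to compound 3 (beyond the scatter) in this assay, small and not clearly beyond the scatter. Compound 3 is estimated to give 45%, within 25% to 65%.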

Compound 3, a percentage reported as inhibition, at one concentration (the size of the read-out at that concentration, not a potency): 41.1%
Compound 3: middle estimate off by 3.9 percentage points, on the high side, within the range that was stated.
By their numbers in this assay, from the lowest: compounds 1, 3 and 2 (each within the scatter of the next).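

In this assay, among the compounds shown here, fluoro in place of hydrogen on an aromatic carbon of the thiazole's phenyl gives a number 3.4 percentage points lower from compound 2 to compound 3 (within the scatter) and so offers the first direct look at this fluorine, which does not separate the two compounds beyond the usual scatter. The full exchange of 5-phenyl-1,3,4-oxadiazol-2-yl for 4-(4-fluorophenyl)-1,3-thiazol-2-yl gives a number 6.4 percentage points higher from compound 1 to compound 3 (within the scatter) and so leaves all three groups at this position, on a saturated chain carbon bound to an amide-type nitrogen in a ring, indistinguishable on this read-out. Nothing available explains these small steps.

On these data alone, the effect of an amine or a carboxylic acid on that phenyl remains open, as does that of a simple methyl in place of the whole aromatic arm. As far as these compounds go, with one concentration behind each number, potency also remains open.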